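The source may hold more compounds than are shown below. What is called first, only, known or untested is meant among the compounds shown, and "the series" means these compounds.

Measured so far, each entry a limit of the assay and not a number:
Compound 1 `COc1cc(-c2cccc3nc(-c4ccc(F)cc4)oc23)cc(OC)c1OC`: > 25000 nM
Compound 2 `COc1ccc(-c2nc3c(-c4cc(OC)c(OC)c(OC)c4)cccc3o2)cc1OC`: > 25000 nM
Compound 3 `COc1cc(OC)cc(-c2nc3c(-c4cc(OC)c(OC)c(OC)c4)cccc3o2)c1`: > 25000 nM

All three were tested in a functional assay on U-251 cells (Homo sapiens) for antiproliferative activity, read by MTT assay, with a stated time of 48 h; a lower number here means a stronger inhibitor, a higher number a weaker inhibitor. Compound 3 stands at > 25000 nM, which is a limit. The whole set shares this position: the limit of > 25000 nM in this assay, at which 3 of the 3 values shown sit.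

Compound 4 `COc1ccc(-c2nc3c(-c4cc(OC)c(OC)c(OC)c4)cccc3o2)cc1F` comes from compound 3 by a single change at the same aromatic carbon: 3-fluoro-4-methoxyphenyl in place of 3,5-dimethoxyphenyl on an aromatic carbon. Among the measured compounds shown here, the one measured step at this place is a step that the two limits leave unreadable from compound 2 to compound 3, so it offers no size to carry over. For the measured compounds named here, with no active compound in the set, no step beyond the scatter is expected, and most likely another limit. The expectation is a number no higher from compound 3 to compound 4 (the limit leaves the size open). Compound 4 is estimated at 25000 nM, with an expected range of 10000 nM to 60000 nM.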

Compound 4, half-maximal inhibitory concentration: 19400 nM
For compound 4 the middle estimate is 1.3-fold (0.11 log units) above the measured one, and the stated range covers the measured number.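

In this assay compound 4 is the first of the compounds shown to read as a number and not as a limit, so a value can be measured with a substituent at this position. The swap to 3-fluoro-4-methoxyphenyl gives an at least 1.2-fold lower number from compound 3 to compound 4 (0.11 log units; that floor lies within the scatter), and fluoro in place of methoxy gives an at least 1.2-fold lower number from compound 2 to compound 4 (0.11 log units; that floor lies within the scatter). Neither floor goes beyond the scatter, and the other compounds remain at a limit: the limit of > 25000 nM in this assay, at which 3 of the 4 values shown sit.

As far as these compounds go, how far the true gaps to those limits reach stays open. So does how an amine or a carboxylic acid at this place would read.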